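The source may report more compounds than this note shows. Statements on the series, on what has been measured and on what is new or still open speak of the compounds shown alone.

Measured so far in a functional assay on cells (Leukemia cell, Homo sapiens) for cytotoxicity, read by sulforhodamine B assay, with a stated time of 48 h; on this read-out higher numbers stand for weaker inhibition of growth and lower numbers for stronger inhibition of growth: compound 1 `COc1ccc(OC)c(-c2cc(-c3ccccc3)nn2-c2ccc(S(N)(=O)=O)cc2)c1` gives 68500 nM; compound 2 `COc1ccc(OC)c(-c2cc(-c3ccccc3)nn2-c2ccc(S(=O)(=O)NC(C)=O)cc2)c1` gives 53400 nM; compound 3 `NS(=O)(=O)c1ccc(-n2nc(-c3ccc(Cl)cc3)cc2-c2cc(O)ccc2O)cc1` gives 61400 nM.

On these three numbers compound 2 sits together with compound 1 and compound 3: the gaps between all three lie within the usual scatter of this assay, so none of them can be set apart from the others.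

Compound 4 `CC(=O)NS(=O)(=O)c1ccc(-n2nc(-c3ccccc3)cc2-c2cc(O)ccc2O)cc1` is the next compound. It differs from compound 2 in one place: 2,5-dihydroxyphenyl in place of 2,5-dimethoxyphenyl on an aromatic carbon. The only step shown among the measured compounds, a 1.3-fold lower number from compound 1 to compound 2 (0.11 log units; within the scatter), concerns the sulfonamide nitrogen, not this position, and is itself within the scatter. Within the data shown here, compound 3 does carry the entering 2,5-dihydroxyphenyl, but it also differs from compound 2 elsewhere, so its number shows only that such a compound lands within the scatter of compound 2.

Among the measured compounds shown here, with no measured step isolating this change, compound 4 is expected to stay close to compound 2, a step of a 1.0-fold higher number from compound 2 to compound 4 (0.01 log units; within the scatter) in this assay, with no direction beyond the scatter. The estimate for compound 4 is therefore 55000 nM, in a range from 25000 nM to 120000 nM.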

Compound 4, concentration for total growth inhibition: 100000 nM
Compound 4: middle estimate off by 1.8-fold (0.26 log units), on the low side; the range from low to high includes it.
By their numbers in this assay, from the lowest: compounds 2, 3, 1 and 4 (each within the scatter of the next).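

Among these compounds, compound 2 and compound 4 differ only in 2,5-dimethoxyphenyl giving way to 2,5-dihydroxyphenyl, so this pair offers the first direct reading of this position in this assay. The exchange gives a 1.9-fold higher number from compound 2 to compound 4 (0.27 log units; within the scatter). Replacing the two methoxy groups with hydroxyl groups brings in hydrogen-bond donors on this ring, yet the resulting difference cannot be separated from ordinary variation between repeated measurements, so this pair shows no clear effect of the change on growth inhibition.

Still open, as far as these compounds go, is whether a different group at this position, such as a 2,5-diaminophenyl or a carboxylic acid-bearing phenyl, would shift the number beyond the scatter. No measurement here gives any explanation for the size of this step.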